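Removing the methoxy group from a cembranoid ester

The compounds below may be only part of what the source reports. "The series", "measured", "known", "first", "only" and "open" are said of these compounds alone.

Measured compounds:
- compound 1, `CC(C)=CC(=O)O[C@@H]1/C=C/[C@@](C)(C/C=C/C(C)(C)O)C/C=C(/CO)CC[C@@H]2O[C@]21C`: 2.25 ug/mL
- compound 2, `COC(C)(C)/C=C/C[C@]1(C)/C=C/[C@@H](OC(=O)C=C(C)C)[C@]2(C)O[C@H]2CC/C(CO)=C\C1`: < 10 ug/mL

Compound 1 carries a free hydroxyl on its side chain and in a functional assay on P388 cells (Mus musculus) for cytotoxicity (a lower number here means that less compound is needed, a higher number that more compound is needed for the effect), compound 1 gives 2.25 ug/mL. Compound 2 has a methyl in place of hydrogen on an oxygen on a saturated carbon. For compound 2 this assay reports only a limit, < 10 ug/mL, so the step that the limit leaves unreadable from compound 1 to compound 2 cannot be sized; the reason is the limit of < 10 ug/mL in this assay, at which 1 of the 2 values shown sits.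

Compound 3, `C=C(C)/C=C/C[C@]1(C)/C=C/[C@@H](OC(=O)C=C(C)C)[C@]2(C)O[C@H]2CC/C(CO)=C\C1`, is not yet measured. It differs from compound 2 by 1-methylethenyl in place of 1-methoxy-1-methylethyl on a double-bonded chain carbon bound to a double-bonded chain carbon. Within the data shown here, no measured step follows this change, and compound 2 itself stands only at a limit, so nothing here gives a direction. Among the measured compounds shown here, compound 3 is therefore expected near the one numerical value shown, that of compound 1, with a wide range, 3 ug/mL (0.6 ug/mL to 15 ug/mL). The step this implies, a step that the limit leaves unreadable from compound 2 to compound 3, is likewise only an estimate.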

Compound 3, concentration for half-maximal effect: < 10 ug/mL
Compound 3 gave a limit, no number; the forecaster's own chance of this, stated with the estimate: 25%; the middle value does not contradict the limit.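

Compound 3, like compound 2, is reported only as a limit, so no step among compound 1, compound 2 and compound 3 can be read in this assay: the limit of < 10 ug/mL in this assay, at which 2 of the 3 values shown sit.

From the compounds shown here alone, whether 1-methylethenyl in place of 1-methoxy-1-methylethyl changes the amount of compound needed, and in which direction, stays open.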